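The compounds below may be only part of what the source reports. "The series", "measured", "known", "first", "only" and "open" are said of these compounds alone.

Compound 1 `Cn1c(-c2cccc(F)c2)nnc1S(C)(=O)=O`: > 200 mg/kg
Compound 2 `Cn1c(-c2cccs2)nnc1S(C)(=O)=O`: > 200 mg/kg

In a functional assay on the whole organism for antagonist activity, with Mus musculus as the target (a higher number here means that more compound is needed for the effect, a lower number that less compound is needed), compound 1 gives > 200 mg/kg, which is a limit of the assay and not a number. Compound 2 gives > 200 mg/kg, and this too is a limit. Within the data shown here, compound 1 therefore stands at the limit of > 200 mg/kg in this assay, at which 2 of the 2 values shown sit, and no measured compound in this small set has yet given a number.

Compound 3 `Cn1c(-c2ccccc2)nnc1S(C)(=O)=O` has not yet been measured. It differs from compound 1 by one change, hydrogen in place of fluoro on an aromatic carbon. Among the measured compounds shown here, no measured step shows what this change does in this assay, so neither its size nor its direction can be read from the data. The expectation is therefore for no step beyond the scatter, and compound 3 may well be reported only as a limit. This expectation rests on compound 1, whose > 200 mg/kg is a limit. The estimated step of a number no higher from compound 1 to compound 3 (the limit leaves the size open) is accordingly expected to be small. For compound 3 the estimate is 200 mg/kg, with an expected range of 80 mg/kg to 400 mg/kg.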

Compound 3, dose for half-maximal effect: 55 mg/kg
Compound 3: the middle estimate sits 3.6-fold (0.56 log units) above what was measured, outside the stated range (below it).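

In this assay, among these compounds, hydrogen in place of fluoro on an aromatic carbon, meta to a large group, is the first change in this set with a readable effect (an at least 3.6-fold lower number from compound 1 to compound 3 (0.56 log units; beyond the scatter)), and that step lies beyond the scatter. The value of compound 1, > 200 mg/kg, is a limit of the assay and not a number, so the step shown is a lower bound and its full size stays open. Among the compounds shown here, compound 3 is the only compound here that gives a number, while the other values shown remain at the limit: the limit of > 200 mg/kg in this assay, at which 2 of the 3 values shown sit.

The compounds shown do not tell whether this position responds to fluoro specifically or to any group other than hydrogen, and a chlorine atom, a methoxy group or a trifluoromethyl group at the same place would bear on that question. They also leave open what happens at the other end of the shared core, for example with an amine or an ether in place of the methylsulfonyl group, and what the methyl group on the core contributes compared with a longer chain.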